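A few compounds are considered here, and "the series" means these few. Any claim that something is new, unique, unknown or untested is made for them only; others in the source may bear on it.

Measured in a functional assay on RS4-11 cells (Homo sapiens) for inhibition, read by CCK-8 assay, with a stated time of 48 h; on this read-out higher numbers stand for weaker inhibition and lower numbers for stronger inhibition:
Compound 1 `COc1cccc(NC(=O)NCCNS(=O)(=O)c2ccc(-c3ccccc3OCc3ccccc3)s2)c1`: > 20000 nM, a limit.
Compound 2 `O=C(NCCNS(=O)(=O)c1ccc(-c2ccccc2OCc2ccccc2)s1)Nc1cccc([N+](=O)[O-])c1`: > 20000 nM, a limit.

Compound 2 has no number in this assay, only the limit > 20000 nM. Among the compounds with values here, the series so far rests on (the limit of > 20000 nM in this assay, at which 2 of the 2 values shown sit). Compound 3 `Cc1cc(C)cc(NC(=O)NCCNS(=O)(=O)c2ccc(-c3ccccc3OCc3ccccc3)s2)c1` carries one change, 3,5-dimethylphenyl in place of 3-nitrophenyl on an amide-type nitrogen. Within the data shown here, the one measured step at this group is a step that the two limits leave unreadable from compound 1 to compound 2, and it offers no size to carry over. With the limit of compound 2 at > 20000 nM as the only anchor, no clear gain in inhibition is expected, and a further limit is the likeliest result. The expected step is a step that the limit leaves unreadable from compound 2 to compound 3. For compound 3 the estimate is 22000 nM, with an expected range of 9000 nM to 45000 nM.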

Compound 3, half-maximal inhibitory concentration: > 50000 nM
Compound 3 gave a limit, no number; the forecaster's own chance of this, stated with the estimate: 75%; middle value at least 2.2-fold (0.35 log units) away from the limit.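

In this assay compound 3 gives > 50000 nM, a limit and not a number. Within the data shown here, compound 1 and compound 2 also stand only as limits, so no step among compound 1, compound 2 and compound 3 can be read. The compounds shown leave open whether any aryl group on the amide-type nitrogen gives a measurable value in this assay.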